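The compounds below may be only part of what the source reports. "The series", "measured", "known", "first", "only" and "open" are said of these compounds alone.

Measured so far in a toxicity assay on THP-1 cells (Homo sapiens) for inhibition; on this read-out higher numbers stand for lower toxicity in this test and lower numbers for higher toxicity in this test:
- compound 1 `COc1ccc(-c2cnc(NC(=O)c3ccccc3O)n2C)cc1`: > 100000 nM
- compound 2 `CCCC(=O)Nc1ncc(-c2ccc(OC)cc2)n1C`: > 100000 nM
- compound 3 `COc1ccc(-c2cnc(NC(=O)CCc3ccccc3)n2C)cc1`: > 100000 nM

Compound 3 gives > 100000 nM, which is a limit and not a number. It shares this position with the others: the limit of > 100000 nM in this assay, at which 3 of the 3 values shown sit.

The next compound is compound 4 `COc1ccc(-c2cnc(NC(=O)c3ccc(O)cc3)n2C)cc1`, and the change is 4-hydroxyphenyl in place of phenethyl on a carbonyl carbon.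

The closest comparison is a step that the two limits leave unreadable from compound 1 to compound 3. The other two, a step that the two limits leave unreadable from compound 1 to compound 2 and a step that the two limits leave unreadable from compound 2 to compound 3, are equally without a readable size. Compound 1 carries 2-hydroxyphenyl on a carbonyl carbon, and its > 100000 nM is also a limit.

In this assay, no step beyond the scatter is expected, and the estimated step is a number no higher from compound 3 to compound 4 (the limit leaves the size open). The estimate for compound 4 is 100000 nM, with an expected range of 50000 nM to 200000 nM.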

Compound 4, half-maximal cytotoxic concentration: > 100000 nM
Compound 4: no number, only a limit; the forecaster's own chance of this, stated with the estimate: 85%; the middle value lies on the limit itself.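

Compound 4 adds no readable step to compound 1, compound 2 or compound 3 in this assay, because all four rest on the same limit: the limit of > 100000 nM in this assay, at which 4 of the 4 values shown sit.

The compounds shown leave open whether these four differ in toxicity at all, and by how much.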